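The compounds below may be only part of what the source reports. "The series", "measured", "known", "first", "only" and "open" are said of these compounds alone.

The study concerns cytotoxicity, followed in an ADME assay on HCT-116 cells (Homo sapiens) for cytotoxicity, read by CellTiter-Glo, with a stated time of 72 h (on this read-out higher numbers stand for weaker inhibition and lower numbers for stronger inhibition), on the compounds shown here. Compound 1 `CC1CCN(C2CCN(S(=O)(=O)c3cccnc3Cl)CC2)CC1` carries a chlorinated pyridine sulfonamide on a piperidine that bears a second, methyl-substituted piperidine. In this assay compound 1 gives > 10000 nM, which is a limit of the assay and not a number. Compound 3 `CC1CCN(C2CCN(S(=O)(=O)c3cccc(C(F)(F)F)c3)CC2)CC1` keeps the same pair of rings under an aryl sulfonamide bearing a trifluoromethyl group. In this assay compound 3 gives > 5000 nM, again a limit rather than a measured number. Compound 2 `Cc1cc(C)c(S(=O)(=O)N2CCC(C(=O)N3CCC(C)CC3)CC2)c(C)c1` is a trimethylphenyl sulfonamide whose piperidine carries a (4-methylpiperidin-1-yl)carbonyl group. In this assay compound 2 gives > 5000 nM, also a limit and not a number. Compound 2 thus stands, like the two other compounds, at a limit: every value shown sits at one, either the limit of > 10000 nM in this assay, at which 1 of the 3 values shown sits, or (the limit of > 5000 nM in this assay, at which 2 of the 3 values shown sit), and no number separates any of them.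

Compound 4 `Cc1cc(C)c(S(=O)(=O)N2CCC(c3ccccc3)CC2)c(C)c1` differs from compound 2 by phenyl in place of (4-methylpiperidin-1-yl)carbonyl on a saturated ring carbon. With only limits to go on, no step beyond the scatter can be expected from this change in this assay. Compound 4 is therefore estimated to give 9000 nM, within 2500 nM to 40000 nM, and the step that the limit leaves unreadable from compound 2 to compound 4 is expected to be small.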

Compound 4, half-maximal inhibitory concentration: > 5000 nM
Compound 4 gave a limit, no number (the forecaster's own chance of this, stated with the estimate: 75%); the middle value lies beyond the limit too.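

In this assay compound 4 gives > 5000 nM, a limit and not a number. Compound 2 also stands at a limit, so no step can be read between compound 2 and compound 4. The compounds shown leave open whether any of these structures has a measurable value in this assay, and how the changes among them would move it: the limit of > 5000 nM in this assay, at which 3 of the 4 values shown sit.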